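Ring-nitrogen aryl variation: clearance expectation for compound 4

The source may hold more compounds than are shown below. What is called first, only, known or untested is meant among the compounds shown, and "the series" means these compounds.

Measured compounds:
compound 1 `COc1ccccc1N1C(=O)C(C)SC1c1cccc(C(=O)NCCCCc2ccccc2)c1` gives 1170 mL.min-1.g-1
compound 2 `O=C(NCCCCc1ccccc1)c1cccc(C2SCC(=O)N2c2ccccn2)c1` gives 492 mL.min-1.g-1
compound 3 `O=C(NCCCCn1cccn1)c1cccc(C2SCC(=O)N2c2cc(F)ccn2)c1` gives 68.2 mL.min-1.g-1

Three analogues of the shared core have been run in an ADME assay on microsomes from liver (Canis lupus familiaris) for metabolic stability, read by LC-MS, using NADPH, with a stated time of 10 min, tested at 0.1 uM; a lower number here means slower removal, a higher number faster removal of the compound. Compound 2 stands second highest of the three numbers. Its nearest neighbour is compound 1, whose number is higher by a margin beyond the scatter; compound 3 lies furthest away, with a number lower than compound 2 by a margin also beyond the scatter. No pair among these three differs in only one place, so no single-point step can be read from them.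

Compound 4 `Cc1cccc(N2C(=O)CSC2c2cccc(C(=O)NCCCCc3ccccc3)c2)c1` has not yet been measured in this assay. It differs from compound 2 as follows: 3-methylphenyl in place of pyridin-2-yl on an amide-type nitrogen in a ring

Compound 1 also carries a six-membered aromatic ring of carbon only on the amide-type nitrogen in the ring, although its core and the substituent on that ring differ from compound 4, and in this assay compound 1 gives 1170 mL.min-1.g-1. On that basis an upward step beyond the scatter is expected for compound 4, the expected size being a 1.8-fold higher number from compound 2 to compound 4 (0.26 log units; within the scatter). Compound 4 is estimated at 900 mL.min-1.g-1, within a range from 450 mL.min-1.g-1 to 1800 mL.min-1.g-1.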

Compound 4, intrinsic clearance in microsomes: 749 mL.min-1.g-1
Compound 4: middle estimate off by 1.2-fold (0.08 log units), on the high side; low and high end bracket the measured number.
By their numbers in this assay, from the lowest: compound 3; then compounds 2, 4 and 1 (each within the scatter of the next, the first and the last beyond it).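

In this assay, among the compounds shown here, the exchange of pyridin-2-yl for 3-methylphenyl on the amide-type nitrogen in the ring gives a 1.5-fold higher number from compound 2 to compound 4 (0.18 log units; within the scatter) and is the first step that differs in one place. Earlier, the ring on this nitrogen could not be separated from the other differences among the compounds; here, with the rest of the structure held constant, a ring with one hetero atom gives way to a ring of carbon only bearing a methyl group, and the two numbers stay within the scatter of each other. No measurement shown here gives a reason for this outcome.

Going by these compounds, the step also combines two changes, the loss of the ring nitrogen and the gain of the methyl group, so the share of each stays open, and plain phenyl or 3-methylpyridin-2-yl at this position would be needed to divide them. Also open, on these data alone, is whether a carboxylic acid or an aminomethyl group on this ring would give a step beyond the scatter, and whether the same exchange gives a similar step when the chain of compound 3 replaces the chain of compound 2.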